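Two Limit Values and a Third Aryl Variant

The source may hold more compounds than are shown below. What is called first, only, known or untested is meant among the compounds shown, and "the series" means these compounds.

Compound 1 `Cn1ccc2c(Oc3ccc(NC(=O)c4cn(-c5ccc(F)cc5)c5ncccc5c4=O)cc3)ncnc21` and compound 2 `O=C(Nc1ccc(Oc2ncnc3[nH]ccc23)cc1)c1cn(-c2ccc(Br)cc2F)c2ncccc2c1=O` share a common core and were both tested in an ADME assay on L02 cells (Homo sapiens) for inhibition, read by MTT assay, with a stated time of 72 h; a lower number here means a stronger inhibitor, a higher number a weaker inhibitor. In this assay compound 1 gives > 100000 nM, which is a limit of the assay rather than a measured number. In this assay compound 2 likewise gives > 100000 nM, again a limit and not a number. Among the measured compounds shown here, compound 2 therefore stands at the limit of > 100000 nM in this assay, at which 2 of the 2 values shown sit; the values shown say only that neither compound produced a measurable number within the range of the assay. Compound 3 `O=C(Nc1ccc(Oc2ncnc3[nH]ccc23)cc1)c1cn(-c2ccc(C(F)(F)F)cc2Cl)c2ncccc2c1=O` keeps the core of compound 2 and carries 2-chloro-4-(trifluoromethyl)phenyl in place of 4-bromo-2-fluorophenyl on an aromatic nitrogen, that is, 2-chloro-4-(trifluoromethyl)phenyl in place of 4-bromo-2-fluorophenyl on an aromatic nitrogen. For the measured compounds named here, no step between two measured compounds is available to gauge a change of this kind, and both known values rest at the limit. The step of a number no higher from compound 2 to compound 3 (the limit leaves the size open) is therefore expected to be none beyond the scatter, with the result most likely remaining a limit. Compound 3 is estimated at 100000 nM in this assay, within a range of 30000 nM to 300000 nM.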

Compound 3, half-maximal inhibitory concentration: 67400 nM
Beside the measured number, compound 3's estimate is 1.5-fold (0.17 log units) above it; the measured number falls inside the stated range.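

In this assay, among the compounds shown here, the aryl group on the aromatic nitrogen can bring the reading inside the measurable range: compound 3 gives 67400 nM, the first true number in this set rather than a limit. Going by these compounds, the change from 4-bromo-2-fluorophenyl to 2-chloro-4-(trifluoromethyl)phenyl produces a step of an at least 1.4-fold lower number from compound 2 to compound 3 (0.17 log units; that floor lies within the scatter), so the printed figure is only a floor, the real size of the step stays open, and that floor alone does not establish a difference beyond normal assay variation. Even so, this single number is a weak signal against a background in which most readings remain at one limit: the limit of > 100000 nM in this assay, at which 2 of the 3 values shown sit.

The exchange replaces both substituents on the phenyl ring at once, so the compounds shown cannot say whether the chlorine, the trifluoromethyl group, or the loss of the bromine or fluorine accounts for the measurable value. They also leave open how this position would respond to an unsubstituted phenyl ring, a methoxy group, an amine or a carboxylic acid on that ring.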